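The source may report more compounds than this note shows. Statements on the series, on what has been measured and on what is new or still open speak of the compounds shown alone.

Compound 1 `O=C1C(Nc2ccc(OC(F)(F)F)cc2)=CC(=O)c2ncncc21`: 1400 nM
Compound 2 `O=C1C(NCc2ccc(F)cc2)=CC(=O)c2ncncc21`: 1700 nM
Compound 3 `O=C1C=CC(=O)c2ncncc21`: 9400 nM

In a functional assay on MIA PaCa-2 cells (Homo sapiens) for cytotoxicity, read by MTT assay, with a stated time of 72 h (on this read-out lower numbers stand for stronger inhibition and higher numbers for weaker inhibition), compound 1 gives the lowest of these three numbers. Compound 1 and compound 2 lie within the scatter of each other, so nothing separates them; compound 3 stands beyond the scatter with a higher number than compound 1. Compound 4 `O=C1C(Nc2ccc(-c3ccc(F)cc3)cc2)=CC(=O)c2ncncc21` differs from compound 1 in one place: 4-fluorophenyl in place of trifluoromethoxy on an aromatic carbon. For the measured compounds named here, no measured pair shows this kind of change, so the step cannot be read from the data. The step expected from compound 1 to compound 4 is a 1.6-fold lower number from compound 1 to compound 4 (0.19 log units; within the scatter), a small shift toward a lower number that may not clear the scatter. Compound 4 is therefore estimated at 900 nM, with a range from 300 nM to 3000 nM.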

Compound 4, half-maximal inhibitory concentration: 3500 nM
Compound 4: middle estimate off by 3.9-fold (0.59 log units), on the low side, and the stated range ends below it.
By their numbers in this assay, from the lowest: compounds 1 and 2 (each within the scatter of the next); then compound 4; then compound 3.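

In this assay the step at this position, a 2.5-fold higher number from compound 1 to compound 4 (0.40 log units; beyond the scatter), lies beyond the scatter, so this aromatic carbon is not indifferent to the group it carries. Here, 4-fluorophenyl in place of trifluoromethoxy does not keep the number of compound 1. No measurement given here accounts for the shift. On these data alone, whether an amine, a methoxy group or a chlorine atom at this place would keep or lower the number stays open. So does whether a carboxylic acid would be tolerated there.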